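A few compounds are considered here, and "the series" means these few. Any claim that something is new, unique, unknown or untested is made for them only; others in the source may bear on it.

Of the compounds shown here, three have been measured in a functional assay on a cell-free system (plasma) for agonist activity at thromboxane A2 receptor (Homo sapiens); a lower number here means a stronger inhibitor, a higher number a weaker inhibitor. Compound 3 `O=C(O)COC/C=C1/C[C@H]2C[C@@H](O)[C@H](/C=N/NC(=O)Nc3ccc(Cl)c(Cl)c3)[C@H]2C1` gives 60 nM. Compound 1 `O=C(O)COC/C=C1/C[C@H]2C[C@@H](O)[C@H](/C=N/NC(=O)Nc3cccc(Cl)c3)[C@H]2C1` gives 180 nM. The two share a core and differ only by hydrogen in place of chloro on an aromatic carbon; this change raised the number a 3.0-fold higher number from compound 3 to compound 1 (0.48 log units; beyond the scatter), so compound 1 is the weaker of the pair. Compound 2 `O=C(O)CCC/C=C1\C[C@H]2CC[C@H](/C=N/NC(=O)Nc3ccc(Cl)c(Cl)c3)[C@H]2C1` is built on a different core, and the difference between the two cores is not broken down here. In this assay compound 2 gives 9000 nM, the highest number of the three.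

Compound 4 `O=C(O)CCC/C=C1\C[C@H]2CC[C@H](/C=N/NC(=O)Nc3cccc(Cl)c3)[C@H]2C1` is not yet measured. It stands to compound 2 exactly as compound 1 stands to compound 3: the change is hydrogen in place of chloro on an aromatic carbon, at the same place on the ring. If the change behaves on the second core as it did on the first, the step from compound 2 to compound 4 is expected to be a 3.0-fold higher number from compound 2 to compound 4 (0.48 log units; beyond the scatter), beside the earlier one, resting on the measured pair a 3.0-fold higher number from compound 3 to compound 1 (0.48 log units; beyond the scatter). Compound 4 is therefore estimated at 27000 nM, with a likely span from 9000 nM to 90000 nM. The span is wide: the step was seen only once and on another core.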

Compound 4, half-maximal inhibitory concentration: 6500 nM
Compound 4: the middle estimate sits 4.2-fold (0.62 log units) above what was measured; the whole stated range lies above it.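

In this assay the change from 3,4-dichlorophenyl to 3-chlorophenyl did not carry over from one core to the other. On the second core it gave a 1.4-fold lower number from compound 2 to compound 4 (0.14 log units; within the scatter) and so left those two compounds indistinguishable, whereas on the core of compound 3 it made the compound weaker, and the two steps really do differ: the same change on two cores in this assay, a 3.0-fold higher number (0.48 log units; beyond the scatter) from compound 3 to compound 1 and a 1.4-fold lower number (0.14 log units; within the scatter) from compound 2 to compound 4, 4.2-fold (0.62 log units) apart, beyond the scatter of two such steps

Within the data shown here, this shows that a step measured on one core could not be relied on for the other, but it does not show why: each core offers only a single pair, and the two cores differ from each other in more than one place.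

Which of those core differences decides the outcome stays open, and a compound carrying only one of them would be needed to tell. Also open, from the compounds shown here alone, is whether a fluoro or a methyl group in place of the chloro that leaves would split between the two cores in the same way.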